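The source may hold more compounds than are shown below. What is called first, only, known or untested is meant among the compounds shown, and "the series" means these compounds.

Working notes on the series. Compound 1 `CCCCCCC[C@H]1C[C@H](Cl)CCN1S(=O)(=O)c1ccc(C)cc1` carries a heptyl group and a chloro group, each on a saturated ring carbon of the shared core. In a functional assay on WiDr cells (Homo sapiens) for antiproliferative activity, read by sulforhodamine B assay, with a stated time of 48 h (on this read-out higher numbers stand for weaker inhibition of growth and lower numbers for stronger inhibition of growth), compound 1 gives 54000 nM. Compound 2 `Cc1ccc(S(=O)(=O)N2CC[C@@H](Cl)C[C@@H]2C2CCCCC2)cc1` differs from compound 1 by cyclohexyl in place of heptyl on a saturated ring carbon. In this assay compound 2 gives 15000 nM, and the change reads as a 3.6-fold lower number from compound 1 to compound 2 (0.56 log units; beyond the scatter). Compound 3 `CCCCCCC[C@H]1C[C@H](Br)CCN1S(=O)(=O)c1ccc(C)cc1` differs from compound 1 by bromo in place of chloro on a saturated ring carbon. In this assay compound 3 returns only a limit, > 100000 nM. Against compound 1 this is an at least 1.8-fold higher number from compound 1 to compound 3 (0.26 log units; that floor lies within the scatter), a figure that rests on (the limit of > 100000 nM in this assay, at which 1 of the 3 values shown sits), so the true size of that step stays open.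

Compound 4 `Cc1ccc(S(=O)(=O)N2CC[C@@H](Br)C[C@@H]2C2CCCCC2)cc1` has not yet been measured in this assay. It differs from compound 3 by cyclohexyl in place of heptyl on a saturated ring carbon. This is the same kind of change as from compound 1 to compound 2, not the same one: there the place lies two ring bonds from the ring atom that bears a chloro group, here two ring bonds from the ring atom that bears a bromo group. Since compound 3 gives only a limit, the starting point is itself open and any expectation for compound 4 is wide. The step is expected to run in the same direction as a 3.6-fold lower number from compound 1 to compound 2 (0.56 log units; beyond the scatter) and is estimated at an at least 2.5-fold lower number from compound 3 to compound 4 (0.39 log units; beyond the scatter). For compound 4 the expected value in this assay is 40000 nM, with an estimated span from 15000 nM to 120000 nM.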

Compound 4, concentration for 50% growth inhibition: 14000 nM
Beside the measured number, compound 4's estimate is 2.9-fold (0.46 log units) above it; the whole stated range lies above it.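

In this assay, cyclohexyl in place of heptyl with the bromo group present gives an at least 7.1-fold lower number from compound 3 to compound 4 (0.85 log units; beyond the scatter), the same direction as with the chloro group present, but the two sizes cannot be compared: the same change on two cores in this assay, a 3.6-fold lower number (0.56 log units; beyond the scatter) from compound 1 to compound 2 and an at least 7.1-fold lower number (0.85 log units; beyond the scatter) from compound 3 to compound 4; the limit leaves it open whether they differ. Bromo in place of chloro with the cyclohexyl group present gives a 1.1-fold lower number from compound 2 to compound 4 (0.03 log units; within the scatter), and this small step cannot be set against the step with the heptyl group present: the same change on two cores in this assay, an at least 1.8-fold higher number (0.26 log units; that floor lies within the scatter) from compound 1 to compound 3 and a 1.1-fold lower number (0.03 log units; within the scatter) from compound 2 to compound 4; the limit leaves it open whether they differ. Compound 3 stands at a limit, > 100000 nM, so the pairs show that the cyclohexyl change carries over between these two cores in direction only, and they do not show that it carries over with a constant size.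

Still open, from the compounds shown here alone, is whether the lower numbers seen with cyclohexyl extend to other groups at the same place, such as a phenyl ring or a shorter chain such as butyl, and whether the step holds with a hydroxyl group or an amine in place of the halogen. Going by these compounds, all four values also come from one cell line and one read-out, so how these steps would read in other cells remains open.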